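Halogen Swap on the Aromatic Ring and Seizure Protection

A few compounds are considered here, and "the series" means these few. Any claim that something is new, unique, unknown or untested is made for them only; others in the source may bear on it.

Compound 1 `CSc1nnc(-c2ccc(F)cc2)n1C`, compound 2 `CSc1nnc(-c2ccccc2Cl)n1C` and compound 3 `CSc1nnc(-c2ccc(Cl)cc2)n1C` share one core and differ only in which halogen sits on the six-membered aromatic ring of carbon only and in where it sits. In a functional assay on the whole organism for antagonist activity, with Mus musculus as the target, in the maximal electroshock model (a higher number here means that more compound is needed for the effect, a lower number that less compound is needed), compound 1 gives > 200 mg/kg, which is a limit of the assay and not a number. In this assay compound 3 gives > 200 mg/kg, again a limit. In this assay compound 2 gives > 50 mg/kg, also a limit. The change from compound 3 to compound 1 is fluoro in place of chloro on an aromatic carbon, and its step that the two limits leave unreadable from compound 3 to compound 1 cannot be sized since both values sit at the limit of > 200 mg/kg in this assay, at which 2 of the 3 values shown sit. The difference between compound 2 and compound 3 is not broken down here.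

Compound 4 `CSc1nnc(-c2ccccc2F)n1C` is still to be measured. The change from compound 2 to compound 4 is fluoro in place of chloro on an aromatic carbon; it is the same kind of change as that from compound 3 to compound 1, but the place differs, being ortho rather than para to a group of 8 heavy atoms. The step from compound 3 to compound 1 gives no readable size, and compound 2 sits at the limit of > 50 mg/kg in this assay, at which 1 of the 3 values shown sits, so the expected step that the limit leaves unreadable from compound 2 to compound 4 rests on little more than the absence of any measured activity in this group. Compound 4 is expected to give about 150 mg/kg in this assay, most likely between 50 mg/kg and 400 mg/kg, and a limit rather than a number is the likelier outcome.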

Compound 4, dose for half-maximal effect: > 200 mg/kg
Compound 4: no number, only a limit (the forecaster's own chance of this, stated with the estimate: 80%); at least 1.3-fold (0.12 log units) between middle value and limit.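

In this assay compound 4 gives > 200 mg/kg as a limit of the assay and not a number. No new step can be read from this result, as the size of the change from compound 2 to compound 4 stays unreadable: the limit of > 200 mg/kg in this assay, at which 3 of the 4 values shown sit. The compounds shown leave open how fluoro and chloro compare in this assay and whether any of these four compounds reaches a measurable dose for half-maximal effect.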